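Ring substitution in the series: from compound 2 to compound 3

The source may report more compounds than this note shows. Statements on the series, on what has been measured and on what is new or still open speak of the compounds shown alone.

Measured so far:
compound 1, `FC(F)(F)c1ccc(/C=C/[C@@H]2CCCCN2)cc1`: 2.82 ug/mL
compound 2, `C(=C/[C@@H]1CCCCN1)\c1ccccc1`: 9.99 ug/mL

In a functional assay on A549 cells (Homo sapiens) for inhibition, read by MTT assay, with a stated time of 24 h (a lower number here means a stronger inhibitor, a higher number a weaker inhibitor), compound 2 gives the highest of the two numbers recorded. Among the measured compounds shown here, its only neighbour is compound 1, which differs by hydrogen in place of trifluoromethyl on an aromatic carbon; that step is a 3.5-fold higher number from compound 1 to compound 2 (0.55 log units; beyond the scatter), a modest change beyond the scatter.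

Compound 3, `COc1ccccc1/C=C/[C@@H]1CCCCN1`, has not yet been measured in this assay. It differs from compound 2 by methoxy in place of hydrogen on an aromatic carbon.

For the measured compounds named here, the single measured step that bears on substitution of the aromatic ring is the one from compound 1 to compound 2, and it is modest in size. As far as these compounds go, compound 3 carries a different group on a different aromatic carbon, so that step is only a loose guide: replacing a ring hydrogen has so far gone with a lower number, but whether methoxy behaves the same is unknown.

For compound 3 a number at or somewhat below that of compound 2 is expected, estimated at 7 ug/mL with a range of 3 ug/mL to 16 ug/mL, which corresponds to a 1.4-fold lower number from compound 2 to compound 3 (0.15 log units; within the scatter).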

Compound 3, half-maximal inhibitory concentration: 4.94 ug/mL
Beside the measured number, compound 3's estimate is 1.4-fold (0.15 log units) above it; the measured number falls inside the stated range.
By their numbers in this assay, from the lowest: compounds 1 and 3 (each within the scatter of the next); then compound 2.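

In this assay methoxy on the aromatic carbon ortho to a group of 8 heavy atoms gives a 2.0-fold lower number from compound 2 to compound 3 (0.31 log units; beyond the scatter) and so shows that this carbon can carry a group of 2 heavy atoms with a modest move towards a lower number. Until now the only ring change was trifluoromethyl, read as a 3.5-fold higher number from compound 1 to compound 2 (0.55 log units; beyond the scatter) in the listed direction, whereas two different groups on the ring now each go with a lower number than hydrogen, and none of the three compounds goes against this. No measurement on hand bears on the reason for the step.

The compounds shown do not separate the effect of the group from that of its place, since methoxy and trifluoromethyl stand on different aromatic carbons, so neither group nor place can be ranked. As far as these compounds go, how an amine, a carboxylic acid or a hydroxy group on this same aromatic carbon would read in this assay remains open, as does whether a longer alkoxy chain there would follow methoxy.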